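Chain-end aryl series: methoxy to hydroxy

The compounds below may be only part of what the source reports. "The series", "measured", "known", "first", "only" and "open" are said of these compounds alone.

Values in a functional assay on SK-OV-3 cells (Homo sapiens) for cytotoxicity; a higher number here means a weaker inhibitor, a lower number a stronger inhibitor:
- compound 1 `C=C/C=C\[C@H](C)[C@H](OC(N)=O)[C@@H](C)[C@H](O)[C@@H](C)C/C(C)=C\[C@H](C)[C@@H](O)[C@@H](C)/C=C\CCc1ccc(C)c(F)c1`: 1000 nM
- compound 2 `C=C/C=C\[C@H](C)[C@H](OC(N)=O)[C@@H](C)[C@H](O)[C@@H](C)C/C(C)=C\[C@H](C)[C@@H](O)[C@@H](C)/C=C\CCc1ccccc1`: 350 nM
- compound 3 `C=C/C=C\[C@H](C)[C@H](OC(N)=O)[C@@H](C)[C@H](O)[C@@H](C)C/C(C)=C\[C@H](C)[C@@H](O)[C@@H](C)/C=C\CCc1cccc(OC)c1`: 370 nM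

Compound 3 stands in the lower pair of the three numbers. That pair is separated only by a 1.1-fold higher number from compound 2 to compound 3 (0.02 log units; within the scatter), and the gap to the top number is a 2.7-fold lower number from compound 1 to compound 3 (0.43 log units; beyond the scatter).

Compound 4 `C=C/C=C\[C@H](C)[C@H](OC(N)=O)[C@@H](C)[C@H](O)[C@@H](C)C/C(C)=C\[C@H](C)[C@@H](O)[C@@H](C)/C=C\CCc1cccc(O)c1` carries hydrogen in place of methyl on an oxygen on an aromatic ring, which reads as methoxy to hydroxy. Among the compounds with values here, no measured step changes this oxygen. The closest one, methoxy in place of hydrogen, is the small step above. Within the data shown here, the only steps beyond the scatter remove 3-fluoro-4-methylphenyl, such as a 2.9-fold lower number from compound 1 to compound 2 (0.46 log units; beyond the scatter), and they are modest.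

An estimated 1.1-fold higher number from compound 3 to compound 4 (0.03 log units; within the scatter) is expected, with no direction beyond the scatter. For compound 4 the expected value is 400 nM, with an estimated range of 170 nM to 1000 nM.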

Compound 4, half-maximal inhibitory concentration: 40 nM
Beside the measured number, compound 4's estimate is 10-fold (1.00 log units) above it, outside the stated range (below it).
By their numbers in this assay, from the lowest: compound 4; then compounds 2 and 3 (each within the scatter of the next); then compound 1.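

In this assay the oxygen on the aromatic ring proves decisive at this position, since hydrogen in place of its methyl gives a 9.3-fold lower number from compound 3 to compound 4 (0.97 log units; beyond the scatter), although compound 2 and compound 3 lie within the scatter of each other. Hydroxy in place of hydrogen gives an 8.8-fold lower number from compound 2 to compound 4 (0.94 log units; beyond the scatter), so the free hydroxy, not merely a group on this aromatic carbon, sets compound 4 apart, and a 25-fold lower number from compound 1 to compound 4 (1.40 log units; beyond the scatter) is the largest step in the set. No evidence on hand bears on this result. On these data alone, whether an amine or a carboxylic acid on this aromatic carbon would match the hydroxy remains open.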